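Cyano for Isopropyl on the Aryl Terminus of Compound 1

A few compounds are considered here, and "the series" means these few. Any claim that something is new, unique, unknown or untested is made for them only; others in the source may bear on it.

Compound 1 `CC#C[C@@H](CC(=O)O)c1ccc(OCc2ccc3nc(-c4ccc(C(C)C)cc4)nn3c2)cc1` and compound 2 `CC#C[C@@H](CC(=O)O)c1ccc(OCc2ccc(CN3CCCc4cccc(OC)c43)s2)cc1` share a phenylpropanoic acid bearing a butynyl arm. In an assay on HEK293 cells for displacement of a labelled ligand from Free fatty acid receptor 1 (Homo sapiens), read by scintillation counting, with a stated time of 2 h (a higher number here means a weaker inhibitor, a lower number a stronger inhibitor), compound 1 gives 32 nM, the higher of the two numbers; in this assay compound 2 gives 27 nM, and the two values lie within the scatter of each other, so nothing separates them. Compound 3 `CC#C[C@@H](CC(=O)O)c1ccc(OCc2ccc3nc(-c4ccc(C#N)cc4)nn3c2)cc1` keeps the core of compound 1 and differs from it only by cyano in place of isopropyl on an aromatic carbon, the change in words being cyano in place of isopropyl on an aromatic carbon. Going by the values given here, no measured pair shows this change, so its size is unknown here. Compound 3 is expected to come out close to compound 1, with at most a small weakening, so the step of a 1.4-fold higher number from compound 1 to compound 3 (0.15 log units; within the scatter) is estimated to stay near the scatter. Compound 3 is therefore estimated at 45 nM, within a range from 15 nM to 150 nM.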

Compound 3, inhibition constant: 35 nM
Compound 3: middle estimate off by 1.3-fold (0.11 log units), on the high side; low and high end bracket the measured number.
By their numbers in this assay, from the lowest: compounds 2, 1 and 3 (each within the scatter of the next).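

In this assay, going by these compounds alone, the change from 4-isopropylphenyl to 4-cyanophenyl gives a 1.1-fold higher number from compound 1 to compound 3 (0.04 log units; within the scatter) and is the first step read at this position. The aromatic carbon on the aryl terminus therefore carries either cyano or isopropyl with no difference that can be told from the scatter, although the entering group brings one hydrogen-bond acceptor and the leaving group brings none. No measurement at hand explains this result.

The compounds shown leave open how far this position stays indifferent to its substituent, since only these two groups are compared there. Whether an amine or a longer alkyl chain at the same place would also stay within the scatter of compound 1 remains unanswered.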